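This account rests on a few compounds, and the source may have more. Where it says the series, first, only, none or still open, it means among the compounds named here.

Series values in a functional assay (muscle tissue) with Cavia porcellus as the target; a higher number here means that more compound is needed for the effect, a lower number that less compound is needed:
- compound 1 `COC(=O)C1=C(C)N=C(C)/C(=C(\O)OC)C1c1cccc(C)c1`: 110 nM
- compound 2 `COC(=O)C1=C(C)N=C(C)/C(=C(\O)OC)C1c1cccc([N+](C)(C)C)c1`: 50100 nM
- compound 3 `COC(=O)C1=C(C)N=C(C)/C(=C(\O)OC)C1c1cccc(OC(=O)c2ccccc2)c1`: not yet measured

Of the two numbers, compound 2 holds the higher, 50100 nM. Going to compound 3 means (a group of 9 heavy atoms (7 carbon, 2 oxygen; one six-membered aromatic ring of carbon only) in place of a group of 4 heavy atoms (3 carbon, 1 nitrogen; no ring), on an aromatic carbon). The group that leaves has a net charge of +1, while the benzoyloxy that enters has no net charge.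

Among the compounds with values here, the only measured step bearing on this is a 460-fold higher number from compound 1 to compound 2 (2.66 log units; beyond the scatter), which installed the same leaving group. Its removal therefore points to a large step towards a lower number in this assay, possibly not all the way to compound 1 at 110 nM. Within the data shown here, no measured compound carries benzoyloxy, so the range stays wide.

The expected change is a 170-fold lower number from compound 2 to compound 3 (2.22 log units; beyond the scatter). For compound 3 the estimate is 300 nM, with an expected range of 40 nM to 3000 nM.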

Compound 3, half-maximal effective concentration: 6310 nM
Estimate against measurement, compound 3: 21-fold (1.32 log units) below; the measured number lies above the stated range.
By their numbers in this assay, from the lowest: compound 1; then compound 3; then compound 2.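

In this assay, exchanging the group with a net charge of +1 for benzoyloxy gives only a 7.9-fold lower number from compound 2 to compound 3 (0.90 log units; beyond the scatter), so an entering group with no net charge does not by itself return the number to the level of compound 1. Benzoyloxy in place of methyl still gives a 57-fold higher number from compound 1 to compound 3 (1.76 log units; beyond the scatter), which shows that a large step at this aromatic carbon does not require a charged group. Nothing available explains the size of either step.

Still open, from the compounds shown here alone, is whether acetoxy or methoxy at this place would fall nearer to compound 1 or to compound 3, which would separate the effect of the benzoyloxy aromatic ring from that of its oxygen link. Also open, going by these compounds, is where a dimethylamino group, an amine with no net charge, would fall relative to compound 2.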